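Methyl on the phenylsulfonyl group: compound 3 to compound 4

The compounds below may be only part of what the source reports. "The series", "measured", "known", "first", "only" and "open" are said of these compounds alone.

Measured so far in a functional assay on A549 cells (Homo sapiens) for cytotoxicity, read by MTT assay, with a stated time of 72 h; on this read-out higher numbers stand for weaker inhibition and lower numbers for stronger inhibition:
- compound 1 `Cc1ccc(S(=O)(=O)c2nc3ccccc3nc2N2CCCC2)cc1`: > 50000 nM (a limit, not a number)
- compound 2 `O=S(=O)(c1ccc(F)cc1)c1nc2ccccc2nc1N1CCCC1`: 31100 nM
- compound 3 `O=S(=O)(c1ccccc1)c1nc2ccccc2nc1N1CCc2ccccc2C1`: 19800 nM

Compound 3 at 19800 nM and compound 2 at 31100 nM lie within the scatter of each other. The only other entry, for compound 1, is a limit, so compound 3 has a single true numerical neighbour.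

Compound 4 `Cc1ccc(S(=O)(=O)c2nc3ccccc3nc2N2CCc3ccccc3C2)cc1` differs from compound 3 by methyl in place of hydrogen on an aromatic carbon. This exact change has not been measured. The nearest evidence is an at least 1.6-fold lower number from compound 1 to compound 2 (0.20 log units; that floor lies within the scatter), a swap of fluoro for methyl with a different group on the shared core. No shift beyond the scatter is therefore expected in this assay, because an at least 1.6-fold lower number from compound 1 to compound 2 (0.20 log units; that floor lies within the scatter) shows none. Within the data shown here, a slightly higher number is the only direction that step hints at. The estimated step is a 1.2-fold higher number from compound 3 to compound 4 (0.08 log units; within the scatter). For compound 4 the expected value is 24000 nM, with an estimated range of 11000 nM to 45000 nM.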

Compound 4, half-maximal inhibitory concentration: > 50000 nM
Compound 4: no number, only a limit; the forecaster's own chance of this, stated with the estimate: 20%; middle value at least 2.0-fold (0.31 log units) from the limit.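

In this assay, going from phenylsulfonyl to (4-methylphenyl)sulfonyl gives an at least 2.5-fold higher number from compound 3 to compound 4 (0.40 log units; beyond the scatter), so a single methyl on this aromatic carbon produces the only readable step shown that lies beyond the scatter. That step is a floor and not a size, because compound 4 carries a limit and not a number: the limit of > 50000 nM in this assay, at which 2 of the 4 values shown sit.

Both compounds with the 4-methylphenyl group, compound 1 and compound 4, now end at a limit, with pyrrolidin-1-yl and 1,2,3,4-tetrahydroisoquinolin-2-yl respectively on the shared core, and the step between them cannot be read.

From the compounds shown here alone, it remains open whether a methoxy group, a chloro atom or an amine on this carbon would track methyl or hydrogen. Going by these compounds, it also remains open whether the step from hydrogen to methyl holds with pyrrolidin-1-yl on the shared core.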